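From One Chlorine to Two on the Pendant Ring

This account rests on a few compounds, and the source may have more. Where it says the series, first, only, none or still open, it means among the compounds named here.

Measured in a functional assay on A549 cells (Homo sapiens) for cytotoxicity, read by MTT assay, with a stated time of 72 h; on this read-out higher numbers stand for weaker inhibition and lower numbers for stronger inhibition:
compound 1 `COc1cccc(/C=C2\CCC/C(=C\c3cccc(OC)c3OC)C2=O)c1` gives 16400 nM.
compound 2 `COc1cccc(/C=C2\CCC/C(=C\c3cc(Cl)cc(Cl)c3)C2=O)c1OC` gives 12500 nM.
compound 3 `COc1ccc(/C=C2\CCC/C(=C\c3ccccc3Cl)C2=O)cc1OC` gives only > 20000 nM, which is a limit of the assay and not a number.

Compound 3 therefore stands at the edge of what this assay resolves, with no exact position among the measured values. Compound 4 `COc1ccc(/C=C2\CCC/C(=C\c3ccc(Cl)c(Cl)c3)C2=O)cc1OC` differs from it in a single place: 3,4-dichlorophenyl in place of 2-chlorophenyl on a double-bonded chain carbon bound to a double-bonded ring carbon. Among the compounds with values here, the only measured step between these compounds, a 1.3-fold lower number from compound 1 to compound 2 (0.12 log units; within the scatter), also exchanged one pendant group for another on a double-bonded chain carbon bound to a double-bonded ring carbon and stayed within the scatter. Within the data shown here, nothing among the measured values points to a change beyond the scatter in this assay from swapping a chlorinated ring of this kind, so no step beyond the scatter is expected, though the limit for compound 3 leaves the starting point uncertain. Compound 4 is expected near 17000 nM, between 7000 nM and 40000 nM. This corresponds to an expected step of an at least 1.1-fold lower number from compound 3 to compound 4 (0.07 log units; that floor lies within the scatter).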

Compound 4, half-maximal inhibitory concentration: 6900 nM
Beside the measured number, compound 4's estimate is 2.5-fold (0.39 log units) above it; measured number outside the range, below it.
By their numbers in this assay, from the lowest: compounds 4, 2 and 1 (each within the scatter of the next, the first and the last beyond it). At a limit, above all of these: compound 3.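

In this assay putting 3,4-dichlorophenyl in place of 2-chlorophenyl on a double-bonded chain carbon bound to a double-bonded ring carbon gives an at least 2.8-fold lower number from compound 3 to compound 4 (0.46 log units; beyond the scatter) at this place. The earlier exchange at the same kind of place gave a 1.3-fold lower number from compound 1 to compound 2 (0.12 log units; within the scatter) and so did not show what this step shows: a change of pendant ring here can move the number beyond the scatter. The true size of the step stays unknown because compound 3 sits at a limit of the assay and not at a number: the limit of > 20000 nM in this assay, at which 1 of the 4 values shown sits.

This change adds a chlorine and also alters where chlorine sits on the ring, and the compounds shown cannot separate the two. On these data alone, how a pendant ring carrying an amine or a carboxylic acid would read at this place also remains open.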